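This account rests on a few compounds, and the source may have more. Where it says the series, first, only, none or still open, it means among the compounds named here.

Measured so far in a functional assay on NCI-H23 cells (Homo sapiens) for antiproliferative activity, read by XTT assay; a higher number here means a weaker inhibitor, a lower number a stronger inhibitor:
- compound 1 `O=c1c(Cc2coc3cccc(OCC4CCCCC4)c3c2=O)coc2ccccc12`: 4130 nM
- compound 2 `Cc1ccc2c(=O)c(Cc3coc4cccc(OCC5CCCCC5)c4c3=O)coc2c1`: 3220 nM

Compound 1 has a single measured neighbour, and the two values lie within the scatter of each other: a 1.3-fold lower number from compound 1 to compound 2 (0.11 log units; within the scatter). Neither compound can therefore be ranked above the other.

The next compound to be tested is compound 3 `COc1cccc2occ(Cc3coc4ccccc4c3=O)c(=O)c12`. Its change from compound 1 is hydrogen in place of cyclohexyl on a saturated chain carbon bound to an oxygen on an aromatic ring, so cyclohexylmethoxy becomes methoxy.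

Among the measured compounds shown here, the only measured step, a 1.3-fold lower number from compound 1 to compound 2 (0.11 log units; within the scatter), is methyl in place of hydrogen on an aromatic carbon. That is a different change, so it gives no size for this one. For the measured compounds named here, no measured compound varies the cyclohexylmethoxy group, and the data offer no direct guide to the effect of losing the cyclohexyl.

In this assay no step beyond the scatter can be firmly expected, only a slight lean towards a higher number. The expected move is a 1.5-fold higher number from compound 1 to compound 3 (0.16 log units; within the scatter). The range is kept wide since this change has not been measured in the series. For compound 3 the estimated value is 6000 nM, with an expected range of 1800 nM to 20000 nM.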

Compound 3, half-maximal inhibitory concentration: 1930 nM
The estimate for compound 3 lay 3.1-fold (0.49 log units) above the measured number; the measured number falls inside the stated range.
By their numbers in this assay, from the lowest: compounds 3, 2 and 1 (each within the scatter of the next, the first and the last beyond it).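

In this assay, the series now has its first variation of the cyclohexylmethoxy group, and cutting it back to methoxy gives a modest step just beyond the scatter (a 2.1-fold lower number from compound 1 to compound 3 (0.33 log units; beyond the scatter)). At this position, hydrogen in place of cyclohexyl on the saturated chain carbon removes the six-membered non-aromatic ring and its 6 carbon atoms without any loss in this read-out, so the cyclohexyl is not needed for the activity of compound 3. The direction of this step rests on one pair only, and nothing at hand bears on the reason for it.

Going by these compounds, whether the number keeps falling or turns back with other groups at this position stays open: a hydroxyl in place of the methoxy, an ethoxy or longer straight chain, a phenyl in place of the cyclohexyl, or a terminal amine or carboxylic acid on the chain would each test this. Also open, on these data alone, is whether the methoxy and the methyl on the aromatic carbon, taken together in one compound, would give a lower number than either change alone.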